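This account rests on a few compounds, and the source may have more. Where it says the series, first, only, none or still open, it means among the compounds named here.

Measured so far:
Compound 1 `CCn1c([C@@H](C)NS(=O)(=O)c2ccc(Cl)cc2)nc2ccc(S(C)(=O)=O)cc21` gives < 5 mL.min-1.g-1 in an ADME assay (liver) for metabolic stability, with Liver microsome (Homo sapiens) as the target, read by LC-MS, using microsomes and NADPH, with a stated time of 5 min, at 37 degrees C (on this read-out higher numbers stand for fast clearance and lower numbers for slow clearance), which is a limit of the assay.
Compound 2 `CCn1c([C@@H](C)NS(=O)(=O)c2cccc(C#N)c2)nc2ccc(C(F)(F)F)cc21` gives > 100 mL.min-1.g-1 in this assay, also a limit.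
Compound 3 `CCn1c([C@@H](C)NS(=O)(=O)c2ccc(NC(C)=O)c(C)c2)nc2ccc(C(F)(F)F)cc21` gives > 100 mL.min-1.g-1 in this assay, also a limit.

Compound 2 therefore stands at the limit of > 100 mL.min-1.g-1 in this assay, at which 2 of the 3 values shown sit, not at a measured number; only compound 1 sits at the limit of < 5 mL.min-1.g-1 in this assay, at which 1 of the 3 values shown sits. Compound 4 `CCn1c([C@@H](C)NS(=O)(=O)c2cnn(C(C)C)c2C)nc2ccc(C(F)(F)F)cc21` differs from compound 2 in one place: 1-isopropyl-5-methyl-1H-pyrazol-4-yl in place of 3-cyanophenyl on a sulfonyl sulfur. Among the measured compounds shown here, no measured pair shows how such an exchange moves clearance, so the size of the step in this assay can only be guessed. The expectation is a modest move toward slower clearance, an at least 1.4-fold lower number from compound 2 to compound 4 (0.15 log units; that floor lies within the scatter), while the compound stays on the fast side. Compound 4 is estimated to give about 70 mL.min-1.g-1, within 25 mL.min-1.g-1 to 150 mL.min-1.g-1.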

Compound 4, intrinsic clearance in microsomes: > 100 mL.min-1.g-1
Compound 4 was reported as a limit; the forecaster's own chance of this, stated with the estimate: 45%; middle value at least 1.4-fold (0.15 log units) from the limit.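

Compound 2 and compound 4 are both reported only as limits in this assay, and the step between them cannot be read. The compounds shown leave open whether this exchange of sulfonyl groups changes clearance at all.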